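The source may hold more compounds than are shown below. What is called first, only, known or untested is meant among the compounds shown, and "the series" means these compounds.

Working notes on a small set of sulfonylurea analogues sharing one core, examined in a functional assay on the whole organism (Mus musculus) for inhibition, at a dose of 150 mg/kg by the oral route; a lower number here means less inhibition, a higher number more inhibition at the dose given (going by the name of the read-out).

Two compounds carry numbers. Compound 1 `Cc1cc(S(=O)(=O)NC(=O)Nc2ccc(Cl)cc2)cc2ccoc12` gives 89% in this assay. Compound 2 `Cc1cc2cc(S(=O)(=O)NC(=O)Nc3ccc(Cl)cc3)ccc2o1` gives 57% in this assay, the lowest of the two numbers; its nearest neighbour is compound 1, whose value is higher by a gap that lies beyond the usual scatter. Among the measured compounds shown here, the two measured compounds differ in more than one place, so no single-point step between measured compounds is available, and nothing can be said about what any one change does to the read-out.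

Compound 3 `O=C(Nc1ccc(Cl)cc1)NS(=O)(=O)c1ccc2occc2c1` is the next compound for this assay. It differs from compound 2 by hydrogen in place of methyl on an aromatic carbon. For the measured compounds named here, with no measured step of this kind to lean on, the expectation is a change from compound 2 to compound 3 of no more than the scatter in this assay, in no set direction, so that the step of a number 2 percentage points lower from compound 2 to compound 3 (within the scatter) is estimated to stay within the scatter. For compound 3 the expected value in this assay is 55%, with a range from 35% to 75%.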

Compound 3, a percentage reported as inhibition, in the whole organism at one dose (the size of the read-out at that dose, not a potency): 100%
Compound 3: the middle estimate sits 45 percentage points below what was measured, outside the stated range (above it).
By their numbers in this assay, from the lowest: compound 2; then compound 1; then compound 3.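

In this assay, among the compounds shown here, the exchange of the methyl for hydrogen on the aromatic carbon next to the ring oxygen gives a number 43 percentage points higher from compound 2 to compound 3 (beyond the scatter), a large step and the first single-place reading at this position. The same exchange at the methyl-bearing carbon of compound 1, which lies elsewhere on the shared core, gives a number 11 percentage points higher from compound 1 to compound 3 (beyond the scatter), a modest step, so both methyl compounds read lower than the methyl-free compound 3, and neither of the two methyl placements shown raises the read-out. Nothing measured here bears on the origin of either step.

The compounds shown compare only methyl and hydrogen on these carbons, so what an ethyl group, a methoxy group or an amine would do at either place stays open. Each number is also the size of the read-out at a single oral dose rather than a potency, which leaves open whether the order of compound 2, compound 1 and compound 3 would hold at other doses.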